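A few compounds are considered here, and "the series" means these few. Any claim that something is new, unique, unknown or untested is made for them only; others in the source may bear on it.

Values in a functional assay on MCF7 cells (Homo sapiens) for antiproliferative activity, read by MTT assay, with a stated time of 72 h; on this read-out lower numbers stand for stronger inhibition and higher numbers for weaker inhibition:
- compound 1 `COc1cc(-c2nc(N(C)C)sc2-c2ccc3ccccc3c2)cc(OC)c1OC`: 2390 nM
- compound 2 `COc1cc(-c2nc(N(C)C)sc2-c2ccc(C)cc2)cc(OC)c1OC`: > 10000 nM (a limit)
- compound 3 `COc1cc(-c2nc(N(C)C)sc2-c2ccc(C(F)(F)F)cc2)cc(OC)c1OC`: > 10000 nM (a limit)

Compound 3 gives a limit rather than a number, and it sits at the limit of > 10000 nM in this assay, at which 2 of the 3 values shown sit. Compound 4 `COc1ccc(-c2sc(N(C)C)nc2-c2cc(OC)c(OC)c(OC)c2)cc1` has methoxy in place of trifluoromethyl on an aromatic carbon, para to a large group: methoxy in place of trifluoromethyl on an aromatic carbon. The closest measured change at this place is a step that the two limits leave unreadable from compound 2 to compound 3, which gives no size to work from. The larger changes, an at least 4.1-fold higher number from compound 1 to compound 2 (0.62 log units; beyond the scatter) and an at least 4.1-fold higher number from compound 1 to compound 3 (0.62 log units; beyond the scatter), show that both substituted phenyl rings give higher numbers than naphthalen-2-yl. A modest fall in the number is therefore expected in this assay, though another limit is quite possible. The expected change is an at least 2.0-fold lower number from compound 3 to compound 4 (0.30 log units; that floor lies within the scatter). Compound 4 is estimated at 5000 nM, within an expected range of 500 nM to 20000 nM.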

Compound 4, half-maximal inhibitory concentration: 8360 nM
The estimate for compound 4 lay 1.7-fold (0.22 log units) below the measured number; the range from low to high includes it.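

Among the compounds with a substituted phenyl ring at this position, only compound 4 gives a number rather than a limit: the limit of > 10000 nM in this assay, at which 2 of the 4 values shown sit. Even so, the comparisons with the two limit compounds establish little, with an at least 1.1-fold lower number from compound 3 to compound 4 (0.07 log units; that floor lies within the scatter) and an at least 1.1-fold lower number from compound 2 to compound 4 (0.07 log units; that floor lies within the scatter), so methoxy is not shown to beat trifluoromethyl or methyl. Naphthalen-2-yl keeps a real lead over 4-methoxyphenyl, with a 3.5-fold higher number from compound 1 to compound 4 (0.54 log units; beyond the scatter).

Still open, on these data alone, is whether a 4-hydroxyphenyl ring, a 4-aminophenyl ring or a longer chain such as ethoxy would bring the number closer to that of compound 1.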